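Replacing cyclopentyl with 3,4-dichlorophenyl on the urea nitrogen

This account rests on a few compounds, and the source may have more. Where it says the series, first, only, none or still open, it means among the compounds named here.

Measured compounds:
compound 1 `O=C(Nc1ccc(Cl)cc1)Nc1cccc(CNc2nccnc2Cl)c1`, 5470 nM
compound 2 `O=C(Nc1cccc(Cl)c1)Nc1cccc(CNc2nccnc2Cl)c1`, 6810 nM
compound 3 `O=C(Nc1cccc(CNc2nccnc2Cl)c1)NC1CCCC1`, > 40000 nM

In a functional assay on T-24 cells (Homo sapiens) for antiproliferative activity, read by MTT assay, with a stated time of 48 h (on this read-out higher numbers stand for weaker inhibition and lower numbers for stronger inhibition), compound 1 gives 5470 nM and compound 2 gives 6810 nM; a 1.2-fold higher number from compound 1 to compound 2 (0.10 log units; within the scatter). For compound 3 the value of > 40000 nM is a limit of the assay, not a number, so compound 3 is known only to sit at the limit of > 40000 nM in this assay, at which 1 of the 3 values shown sits. The steps of an at least 7.3-fold higher number from compound 1 to compound 3 (0.86 log units; beyond the scatter) and an at least 5.8-fold higher number from compound 2 to compound 3 (0.76 log units; beyond the scatter) show that a chlorophenyl on that nitrogen gives the stronger inhibition. Compound 4 `O=C(Nc1cccc(CNc2nccnc2Cl)c1)Nc1ccc(Cl)c(Cl)c1` differs from compound 3 by 3,4-dichlorophenyl in place of cyclopentyl on an amide-type nitrogen. Since this returns a chlorophenyl to the position held by cyclopentyl, compound 4 is expected to fall near compound 1 and compound 2, with an at least 10-fold lower number from compound 3 to compound 4 (1.00 log units; beyond the scatter). Compound 4 is therefore estimated at 4000 nM, within 1500 nM to 12000 nM.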

Compound 4, half-maximal inhibitory concentration: 5210 nM
Beside the measured number, compound 4's estimate is 1.3-fold (0.11 log units) below it; measured number inside the range.
By their numbers in this assay, from the lowest: compounds 4, 1 and 2 (each within the scatter of the next). At a limit, above all of these: compound 3.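

In this assay, 3,4-dichlorophenyl in place of cyclopentyl on the amide-type nitrogen gives an at least 7.6-fold lower number from compound 3 to compound 4 (0.88 log units; beyond the scatter), so the gain seen with either single chlorophenyl also holds for a dichlorinated ring. The second chloro brings no readable change, with a 1.3-fold lower number from compound 2 to compound 4 (0.12 log units; within the scatter) and a 1.0-fold lower number from compound 1 to compound 4 (0.02 log units; within the scatter). The value of compound 3 is a limit, and the steps from it are bounds only: the limit of > 40000 nM in this assay, at which 1 of the 4 values shown sits.

Still open, on these data alone, is whether an unsubstituted phenyl keeps this level, and what a methoxy group or a carboxylic acid on that ring would do.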